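Aryl swap at the oxadiazole: methoxyphenyl to pyridinyl

A few compounds are considered here, and "the series" means these few. Any claim that something is new, unique, unknown or untested is made for them only; others in the source may bear on it.

Compound 1 `COc1ccc(-c2nnc(SCCn3c([N+](=O)[O-])cnc3C)o2)cc1` is the reference point of this small set. Among the measured compounds shown here, in a functional assay on SGC-7901 cells (Homo sapiens) for cytotoxicity, read by MTT assay, with a stated time of 48 h (on this read-out lower numbers stand for stronger inhibition and higher numbers for weaker inhibition), compound 1 gives 10200 nM, the lowest of the three numbers so far. Compound 2 `CCOc1ccc(-c2nnc(SCCn3c([N+](=O)[O-])cnc3C)o2)cc1` gives 14100 nM, and the move a 1.4-fold higher number from compound 1 to compound 2 (0.14 log units; within the scatter) stays within the scatter. Compound 3 `Cc1ncc([N+](=O)[O-])n1CCSc1nnc(-c2ccc(N(C)C)cc2)o1` gives 32800 nM; here a 3.2-fold higher number from compound 1 to compound 3 (0.51 log units; beyond the scatter) and a 2.3-fold higher number from compound 2 to compound 3 (0.37 log units; beyond the scatter) both lie beyond the scatter, so the exchange of the alkoxy group for a dimethylamino group costs a modest amount.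

Compound 4 `Cc1ncc([N+](=O)[O-])n1CCSc1nnc(-c2ccccn2)o1` changes a different part of the molecule: pyridin-2-yl in place of 4-methoxyphenyl on an aromatic carbon. For the measured compounds named here, no measured pair exchanges the whole six-membered ring, so the three recorded steps bear on the new step only indirectly. They show that the shared core tolerates small edits on the aromatic ring with at most modest loss, the largest being a 3.2-fold higher number from compound 1 to compound 3 (0.51 log units; beyond the scatter). A loss of similar order, or none beyond the scatter, is therefore the working expectation for a 1.6-fold higher number from compound 1 to compound 4 (0.20 log units; within the scatter), with the uncertainty widened for the untested ring exchange. Compound 4 is expected to give about 16000 nM, within a range of 5000 nM to 50000 nM.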

Compound 4, half-maximal inhibitory concentration: 30000 nM
Beside the measured number, compound 4's estimate is 1.9-fold (0.27 log units) below it, within the range that was stated.
By their numbers in this assay, from the lowest: compounds 1 and 2 (each within the scatter of the next); then compounds 4 and 3 (each within the scatter of the next).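

In this assay the exchange of the whole aromatic ring on the shared core carries a modest cost, with a 2.9-fold higher number from compound 1 to compound 4 (0.47 log units; beyond the scatter) as the step. The earlier steps shown here edited only the group on the ring, whereas here pyridin-2-yl replaces 4-methoxyphenyl, and compound 4 falls within the scatter of compound 3, so this ring exchange and the dimethylamino edit end in the same band of values. No measured property is at hand to account for this step.

The compounds shown do not separate the contribution of the ring nitrogen from that of the lost methoxy group. An unsubstituted phenyl group, or a pyridin-3-yl or pyridin-4-yl group, on this same aromatic carbon would bear directly on that question.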